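Swapping a Methoxymethyl Tail for Dimethylamino

The source may report more compounds than this note shows. Statements on the series, on what has been measured and on what is new or still open speak of the compounds shown alone.

Of the compounds shown here, three built on a shared core have been measured in a physicochemical assay for solubility, read by HPLC; a higher number here means a more soluble compound, a lower number a less soluble compound. Compound 1 `O=[N+]([O-])c1nccn1CS(=O)(=O)NCCN1CCCC1` gives 16100000 nM. Compound 2 `COCCNS(=O)(=O)CCn1ccnc1[N+](=O)[O-]` gives 59400000 nM, and compound 3 `COCCCNS(=O)(=O)CCn1c([N+](=O)[O-])cnc1C` gives 17000000 nM. Among these three numbers compound 3 stands second highest: its nearest neighbour is compound 1, whose number is lower by a margin within the usual scatter of this assay, while compound 2 sits furthest from it, higher by a margin beyond the scatter.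

Compound 4 `Cc1ncc([N+](=O)[O-])n1CCS(=O)(=O)NCCN(C)C` has not yet been measured. It differs from compound 3 in a single place: dimethylamino in place of methoxymethyl on a saturated chain carbon, two bonds along the chain from a sulfonamide nitrogen. Within the data shown here, no measured pair shows this exact exchange, so its effect cannot be read off directly. The expectation instead rests on compound 3 giving 17000000 nM and compound 1 giving 16100000 nM, two numbers that lie close together despite different chains on the sulfonamide nitrogen. The step from compound 3 to compound 4 in this assay is therefore expected to be a 1.2-fold higher number from compound 3 to compound 4 (0.07 log units; within the scatter), with no direction beyond the scatter. Compound 4 is estimated at 20000000 nM, within a range from 8000000 nM to 50000000 nM.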

Compound 4, solubility: 46800000 nM
Compound 4: middle estimate off by 2.3-fold (0.37 log units), on the low side, and the stated range covers the measured number.
By their numbers in this assay, from the lowest: compounds 1 and 3 (each within the scatter of the next); then compounds 4 and 2 (each within the scatter of the next).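

Among these compounds, at this place on a saturated chain carbon, two bonds along the chain from a sulfonamide nitrogen, putting dimethylamino in place of methoxymethyl gives a 2.8-fold higher number from compound 3 to compound 4 (0.44 log units; beyond the scatter) in this assay and this is the first step here read between two compounds that differ in one place. It shows that this end of the chain is not a silent spot in this assay, even though the two groups have the same count of heavy atoms and neither holds a ring, with one nitrogen standing for one oxygen. Nothing measured here explains why the number moves.

From the compounds shown here alone, whether a morpholine or a carboxylic acid at this place would give a step of similar size or direction remains open. Also open, going by these compounds, is whether a longer chain ending in dimethylamino would keep this step, and whether the same exchange would act alike on the core of compound 2.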